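The compounds below may be only part of what the source reports. "The series", "measured", "known", "first", "only" and "open" are said of these compounds alone.

Of the compounds shown here, three share one core and have been tested in an assay on isolated protein for inhibition of proto-oncogene tyrosine-protein kinase receptor Ret (Homo sapiens), read by mobility shift assay, with a stated time of 1 h, tested at 10 uM; a higher number here means more inhibition at the concentration tested (going by the name of the read-out), a lower number less inhibition. Compound 1 `CN(C)CCn1cnnc1-c1cc(Oc2ccc(NC(=O)Nc3cccc(C(F)(F)F)c3)cc2F)ccn1` gives 77.7%. Among the compounds with values here, compound 2 `CCN(CC)CCn1cnnc1-c1cc(Oc2ccc(NC(=O)Nc3cccc(C(F)(F)F)c3)cc2F)ccn1` gives 72.1%, and the one measured step, a number 5.6 percentage points lower from compound 1 to compound 2 (within the scatter), shows no change beyond the scatter. Compound 3 `CN(C)CCCn1cnnc1-c1cc(Oc2ccc(NC(=O)Nc3ccc(Cl)c(C(F)(F)F)c3)cc2F)ccn1` gives 79.3%, the largest of the three numbers, though its gaps to compound 1 and compound 2 both lie within the scatter.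

The next compound is compound 4 `CN(C)CCCn1cnnc1-c1cc(Oc2ccc(NC(=O)Nc3cccc(C(F)(F)F)c3)cc2F)ccn1`. It differs from compound 3 in one place: hydrogen in place of chloro on an aromatic carbon. Within the data shown here, no measured step touches this part of the molecule, so the step from compound 1 to compound 2 gives no direct guide. Compound 1, which carries the same aryl group as compound 4, gives a number close to that of compound 3. The change is therefore expected to bring no shift beyond the scatter, a number 3.3 percentage points lower from compound 3 to compound 4 (within the scatter). Compound 4 is estimated at 76%, with a range from 62% to 88%.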

Compound 4, a percentage reported as inhibition, at one concentration (the size of the read-out at that concentration, not a potency): 85.6%
Compound 4: the middle estimate sits 9.6 percentage points below what was measured; measured number inside the range.
By their numbers in this assay, from the lowest: compounds 2, 1, 3 and 4 (each within the scatter of the next, the first and the last beyond it).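

Swapping chloro for hydrogen on the aromatic ring, turning 4-chloro-3-(trifluoromethyl)phenyl into 3-(trifluoromethyl)phenyl, gives a number 6.3 percentage points higher from compound 3 to compound 4 (within the scatter), so this position accepts either atom with no shift that can be told from the scatter. Within the data shown here, on the chain, (dimethylamino)methyl in place of dimethylamino gives a number 7.9 percentage points higher from compound 1 to compound 4 (within the scatter), while the same group in place of diethylamino gives a number 13.5 percentage points higher from compound 2 to compound 4 (beyond the scatter), the first step here to clear the scatter, though only a modest one. No measurement is available that would explain these numbers.

Going by these compounds, whether fluoro or methoxy at the chloro position would behave like chloro and hydrogen remains open. So does the effect of a longer chain, such as one with an added methylene group, or of a cyclic amine such as morpholine or pyrrolidine in place of dimethylamino.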